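Replacing the 1,5-dimethyl-1H-pyrazol-4-yl group of compound 3

A few compounds are considered here, and "the series" means these few. Any claim that something is new, unique, unknown or untested is made for them only; others in the source may bear on it.

Three compounds built on a shared core have values in a physicochemical assay for lipophilicity, using the shake flask method, measured as octanol-water partition, at pH 7.4; a higher number here means a more lipophilic compound, a lower number a more polar compound. Compound 1 `CC(=O)N[C@@H]1CCC[C@H](C(=O)Nc2cc(-c3cnn4c3CCCC4)ccn2)C1` gives 2.4, and compound 2 `CC(=O)N[C@@H]1CCC[C@H](C(=O)Nc2cc(-c3cnn4c3CCCC4)c(F)cn2)C1` gives 2.9. Compound 3 `CC(=O)N[C@@H]1CCC[C@H](C(=O)Nc2cc(-c3cnn(C)c3C)c(Cl)cn2)C1` gives 2.6, which lies within the scatter of both compound 1 and compound 2, even though those two are separated by more than the scatter.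

Compound 4 `CC(=O)N[C@@H]1CCC[C@H](C(=O)Nc2cc(-c3nnn4ccccc34)c(Cl)cn2)C1` has not yet been measured. It differs from compound 3 in one place: a group of 9 heavy atoms (6 carbon, 3 nitrogen; one five-membered aromatic ring with 3 hetero atoms, one six-membered aromatic ring with 1 hetero atom) in place of a group of 7 heavy atoms (5 carbon, 2 nitrogen; one five-membered aromatic ring with 2 hetero atoms), on an aromatic carbon. The change sits on an aromatic carbon, ortho to a chloro group and opposite the ring nitrogen.

Among the measured compounds shown here, only one measured step is available: a number 0.50 log units higher from compound 1 to compound 2 (beyond the scatter), with fluoro in place of hydrogen on an aromatic carbon. For the measured compounds named here, that is a different kind of change, and no measured pair isolates a replacement of the 1,5-dimethyl-1H-pyrazol-4-yl group. It therefore offers only a loose guide to how far a single edit can move this assay. A step of that modest size in either direction remains possible, but the central expectation is no step beyond the scatter. The estimated change is a number 0.10 log units higher from compound 3 to compound 4 (within the scatter). For compound 4 the estimated value is 2.7, with an expected range of 2.2 to 3.2.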

Compound 4, distribution coefficient: 2
Estimate against measurement, compound 4: 0.70 log units above; the measured number lies below the stated range.
By their numbers in this assay, from the lowest: compound 4; then compounds 1, 3 and 2 (each within the scatter of the next, the first and the last beyond it).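

Among the compounds shown here, at this position, on an aromatic carbon ortho to a chloro group and opposite the ring nitrogen, the earlier compounds gave no direct reading, and the exchange of the 1,5-dimethyl-1H-pyrazol-4-yl group now supplies one in this assay: a number 0.60 log units lower from compound 3 to compound 4 (beyond the scatter). The entering group has more heavy atoms, one more nitrogen and one more hydrogen-bond acceptor than the group it replaces, yet the step runs downward, so in this one pair a larger group does not bring a higher number. For the compounds shown here, until now the only step read was the upward one for fluoro in place of hydrogen, and this result adds a step beyond the scatter in the opposite direction, though no supporting measurement bears on why it runs that way.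

A single pair cannot separate what the added nitrogen, the second ring or the greater size each contribute to the step. It also leaves open how a phenyl group or a morpholine would read at this position, and whether the same exchange would give a similar step with fluoro or hydrogen in place of the chloro group.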